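Propanoyl to Acetyl on the Shared Core

The source may hold more compounds than are shown below. What is called first, only, known or untested is meant among the compounds shown, and "the series" means these compounds.

Measured in a functional assay on MCF7 cells (Homo sapiens) for inhibition, read by MTT assay, with a stated time of 96 h; a higher number here means a weaker inhibitor of growth, a lower number a stronger inhibitor of growth:
- compound 1 `C=CCOC(=O)SCCCCCCNC(=O)c1cc(-c2ccncc2)n[nH]1`: 12600 nM
- compound 2 `CCCC(=O)SCCCCCCNC(=O)c1cc(-c2ccncc2)n[nH]1`: 12100 nM
- compound 3 `CCC(=O)SCCCCCCNC(=O)c1cc(-c2ccncc2)n[nH]1`: > 50000 nM (a limit, not a number)

Not yet measured: compound 4 `CC(=O)SCCCCCCNC(=O)c1cc(-c2ccncc2)n[nH]1`.

Compound 3 sits at the limit of > 50000 nM in this assay, at which 1 of the 3 values shown sits. The next change is hydrogen in place of methyl on a saturated chain carbon bound to a carbonyl carbon, which turns propanoyl into acetyl.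

The closest measured change also puts hydrogen in place of methyl on a saturated chain carbon, and it gave an at least 4.1-fold higher number from compound 2 to compound 3 (0.61 log units; beyond the scatter). The other step into compound 3 gave an at least 3.9-fold higher number from compound 1 to compound 3 (0.59 log units; beyond the scatter). The remaining step, a 1.0-fold lower number from compound 1 to compound 2 (0.02 log units; within the scatter), shows that compound 1 and compound 2 do not differ beyond the scatter, and it says little about this change.

Compound 3 offers only a limit, so the size of any step from it cannot be fixed. A modest further step toward a higher number is expected in this assay, and the assay will quite likely report a limit again. The expected change is a step that the limit leaves unreadable from compound 3 to compound 4. The estimated value for compound 4 is 60000 nM, with an expected range from 25000 nM to 150000 nM.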

Compound 4, concentration for 50% growth inhibition: 24900 nM
The estimate for compound 4 lay 2.4-fold (0.38 log units) above the measured number; measured number outside the range, below it.
By their numbers in this assay, from the lowest: compounds 2, 1 and 4 (each within the scatter of the next, the first and the last beyond it). At a limit, above all of these: compound 3.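

Putting hydrogen in place of methyl on this saturated chain carbon bound to a carbonyl carbon, which turns propanoyl into acetyl, gave an at least 2.0-fold lower number from compound 3 to compound 4 (0.30 log units; that floor lies within the scatter) in this assay, so this change points the opposite way to the earlier hydrogen-for-methyl step further along the chain, although its floor alone does not clear the scatter. For the compounds shown here, compound 3 remains the only compound held at a limit: the limit of > 50000 nM in this assay, at which 1 of the 4 values shown sits. Among the measured numbers, acetyl gave a 2.1-fold higher number from compound 2 to compound 4 (0.31 log units; beyond the scatter), while the other comparison gave a 2.0-fold higher number from compound 1 to compound 4 (0.30 log units; within the scatter); the number therefore does not climb steadily as the acyl group shortens, and compound 3 is the one that goes against a steady order.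

As far as these compounds go, how far the true value of compound 3 lies beyond its limit stays open, so the size of the step out of it remains unfixed. Also open, from the compounds shown here alone, is whether a longer chain, a benzoyl group or an amine on the carbonyl carbon would shift the number in this assay.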